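This account rests on a few compounds, and the source may have more. Where it says the series, first, only, none or still open, it means among the compounds named here.

Among the three compounds with a measured number, compound 2 `CCCCCCCCCCCC(=O)OC[C@H](CSC[C@@H](N)C(=O)NC1(CO)CC1)OC(=O)CCCCCCCCCCC` gives the lowest reading in an assay on HEK293 cells for agonist activity at Toll-like receptor 2 (Homo sapiens) (a higher number here means that more compound is needed for the effect, a lower number that less compound is needed), at 265 nM. Compound 3 `CCCCCCCCCCCC(=O)OC[C@H](CSC[C@@H](N)C(=O)NCCCn1ccnc1)OC(=O)CCCCCCCCCCC` stands nearest with 410 nM, a gap that stays within the scatter; compound 1 `CCCCCCCCCCCC(=O)OC[C@H](CSC[C@@H](N)C(=O)NCCCC(C)(C)CO)OC(=O)CCCCCCCCCCC` lies furthest, at 30700 nM, a difference of a 120-fold lower number from compound 1 to compound 2 (2.06 log units; beyond the scatter). Compound 4 `CCCCCCCCCCCC(=O)OC[C@H](CSC[C@@H](N)C(=O)NC(C)CCN(CC)CC)OC(=O)CCCCCCCCCCC` carries 3-(diethylamino)-1-methylpropyl in place of 1-(hydroxymethyl)cyclopropyl on an amide-type nitrogen. Among the compounds with values here, two measured steps touch the same amide-type nitrogen: a 120-fold lower number from compound 1 to compound 2 (2.06 log units; beyond the scatter), a large one, and a 1.5-fold higher number from compound 2 to compound 3 (0.19 log units; within the scatter), a small one. Since compound 3 with its 3-(1H-imidazol-1-yl)propyl chain stays close to compound 2 while compound 1 with its 4-(hydroxymethyl)-4-methylpentyl chain falls far behind, an expected move of a 2.6-fold higher number from compound 2 to compound 4 (0.42 log units; beyond the scatter) toward a higher number is estimated, with compound 4 expected at 700 nM, between 150 nM and 4000 nM.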

Compound 4, half-maximal effective concentration: 257 nM
Compound 4: the middle estimate sits 2.7-fold (0.44 log units) above what was measured; low and high end bracket the measured number.
By their numbers in this assay, from the lowest: compounds 4, 2 and 3 (each within the scatter of the next); then compound 1.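

At the amide-type nitrogen in this assay, 3-(diethylamino)-1-methylpropyl, with no ring and 0 hydrogen-bond donors, stays level with both earlier low readers: a 1.0-fold lower number from compound 2 to compound 4 (0.01 log units; within the scatter), and a 1.6-fold lower number from compound 3 to compound 4 (0.20 log units; within the scatter). Compound 1 remains the only one apart, with a 120-fold lower number from compound 1 to compound 4 (2.08 log units; beyond the scatter), so three quite different groups at this nitrogen now share one range. Nothing available explains why these groups read alike or why compound 1 differs. From the compounds shown here alone, what a plain propyl chain or a carboxylic acid at the chain end would give stays open, as does the separate contribution of the 1-methyl branch and the diethylamino end in compound 4.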